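The source may hold more compounds than are shown below. What is called first, only, known or untested is meant among the compounds shown, and "the series" means these compounds.

Compound 1 `CCCCN(CC)c1cc(C)nc2c1NC(=O)CN2c1ccc(C)cc1Cl`: 4.4 nM
Compound 2 `CCCCN(CC)c1cc(C)nc2c1NC(=O)CN2c1ccc(Br)cc1Br`: 1.3 nM
Compound 3 `CCN(C)c1cc(C)nc2c1N(CCCCF)C(=O)CN2c1ccc(C(C)C)cc1Br`: 13.9 nM

Of the compounds shown here, three sharing one core have been measured in an assay on HEK-293T cells for displacement of a labelled ligand from corticotropin-releasing factor receptor 1 (Homo sapiens), read by scintillation counting, with a stated time of 2 h; on this read-out lower numbers stand for stronger inhibition and higher numbers for weaker inhibition. Compound 1 gives 4.4 nM, which places it second highest of the three numbers; compound 3 is nearest with 13.9 nM, and compound 2 is furthest with 1.3 nM. Compound 4 `CCCCN(CC)c1cc(C)nc2c1NC(=O)CN2c1ccc(I)cc1C` has not yet been measured. It differs from compound 1 in one place: 4-iodo-2-methylphenyl in place of 2-chloro-4-methylphenyl on a nitrogen on an aromatic ring in a ring. Among the compounds with values here, the one measured step that bears on this change is a 3.4-fold lower number from compound 1 to compound 2 (0.53 log units; beyond the scatter), in which the aryl group on the same nitrogen was exchanged. Compound 3 differs from compound 1 in several places at once and offers no single-change comparison. Because a 3.4-fold lower number from compound 1 to compound 2 (0.53 log units; beyond the scatter) lowered the number when that aryl group was exchanged, a step in the same direction is expected for compound 4, though its size is uncertain as the entering group pairs iodine with methyl rather than two bromines. Compound 4 is therefore estimated at 2.5 nM, with a range from 0.8 nM to 8 nM, which means an expected step of a 1.8-fold lower number from compound 1 to compound 4 (0.25 log units; within the scatter).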

Compound 4, inhibition constant: 3.4 nM
Estimate against measurement, compound 4: 1.4-fold (0.13 log units) below; low and high end bracket the measured number.
By their numbers in this assay, from the lowest: compound 2; then compounds 4 and 1 (each within the scatter of the next); then compound 3.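

Exchanging 2-chloro-4-methylphenyl for 4-iodo-2-methylphenyl on this nitrogen gives a 1.3-fold lower number from compound 1 to compound 4 (0.11 log units; within the scatter), so this change of aryl group, which keeps the same count of heavy atoms, leaves the number within the scatter. Set against the 2,4-dibromophenyl group, the same 4-iodo-2-methylphenyl group gives a 2.6-fold higher number from compound 2 to compound 4 (0.42 log units; beyond the scatter), which shows that the earlier step from the 2-chloro-4-methylphenyl group to the 2,4-dibromophenyl group does not extend to every aryl exchange at this nitrogen. No measurement at hand gives a reason for this difference.

Each of these aryl groups differs from the others at both substituents, so the contribution of a single substituent cannot be separated. Also open, as far as these compounds go, is how a methoxy group or a nitrile in place of the iodine would compare on the same core.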